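This account rests on a few compounds, and the source may have more. Where it says the series, first, only, none or still open, it means among the compounds named here.

Measured in a functional assay on HOP-62 cells (Homo sapiens) for inhibition, read by sulforhodamine B assay, with a stated time of 48 h; a lower number here means a stronger inhibitor of growth, a higher number a weaker inhibitor of growth:
- compound 1 `O=C(Nc1cccc(-n2cc(-c3ccncc3)c(-c3ccc(Cl)c(O)c3)n2)c1)Nc1cccc(C(F)(F)F)c1`: compound 1 gives > 32500 nM, which is a limit of the assay and not a number.
- compound 2 `COc1cc(-c2nn(-c3cccc(NC(=O)Nc4cccc(C(F)(F)F)c4)c3)cc2-c2ccncc2)ccc1Cl`: compound 2 gives 4070 nM.
- compound 3 `COc1cc(-c2nn(-c3cccc(NC(=O)Nc4ccc(Cl)c(C(F)(F)F)c4)c3)cc2-c2ccncc2)ccc1Cl`: compound 3 gives 6490 nM.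

Compound 4 `O=C(Nc1cccc(-n2cc(-c3ccncc3)c(-c3ccc(Cl)c(O)c3)n2)c1)Nc1ccc(Cl)c(C(F)(F)F)c1` is not yet measured in this assay. It differs from compound 3 by hydrogen in place of methyl on an oxygen on an aromatic ring. The same change is made from compound 2 to compound 1, (hydrogen in place of methyl on an oxygen on an aromatic ring), where it gave an at least 7.9-fold higher number from compound 2 to compound 1 (0.90 log units; beyond the scatter). The value of compound 1 sits at the limit of > 32500 nM in this assay, at which 1 of the 3 values shown sits. The two cores differ by chloro in place of hydrogen on an aromatic carbon, a step of a 1.6-fold higher number from compound 2 to compound 3 (0.20 log units; within the scatter). As the place of the change reads the same word for word in both pairs, it is the same change. Compound 4 is expected to show a step of a 7.7-fold higher number from compound 3 to compound 4 (0.89 log units; beyond the scatter), resting on an at least 7.9-fold higher number from compound 2 to compound 1 (0.90 log units; beyond the scatter). Compound 4 is estimated at 50000 nM, likely between 20000 nM and 150000 nM, and a limit rather than a number is the likely report.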

Compound 4, concentration for total growth inhibition: 7830 nM
Estimate against measurement, compound 4: 6.4-fold (0.81 log units) above; measured number outside the range, below it.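

In this assay the methoxy to hydroxy change gives a 1.2-fold higher number from compound 3 to compound 4 (0.08 log units; within the scatter), so its effect did not carry over from the core of compound 2 to the core of compound 3: the same change on two cores in this assay, an at least 7.9-fold higher number (0.90 log units; beyond the scatter) from compound 2 to compound 1 and a 1.2-fold higher number (0.08 log units; within the scatter) from compound 3 to compound 4, at least 6.6-fold (0.82 log units) apart, beyond the scatter of two such steps

Read the other way, chloro in place of hydrogen gives an at least 4.1-fold lower number from compound 1 to compound 4 (0.61 log units; beyond the scatter), so that step also depends on the core: the same change on two cores in this assay, a 1.6-fold higher number (0.20 log units; within the scatter) from compound 2 to compound 3 and an at least 4.1-fold lower number (0.61 log units; beyond the scatter) from compound 1 to compound 4, at least 6.6-fold (0.82 log units) apart, beyond the scatter of two such steps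

Compound 1 gives > 32500 nM, which is a limit and not a number, so the pairs show a dependence on the core but neither the true size of that step nor a rule for further cores: the limit of > 32500 nM in this assay, at which 1 of the 4 values shown sits.

The compounds shown leave open whether an ethoxy or an amino group in place of the hydroxy would behave like the methoxy or the hydroxy on each core. From the compounds shown here alone, whether the dependence on the core extends beyond these two cores also remains open.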